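Ring size at the amide carbonyl: cyclobutyl to cyclopentyl

The source may report more compounds than this note shows. Statements on the series, on what has been measured and on what is new or still open speak of the compounds shown alone.

Measured compounds in an assay for inhibition of Nitric oxide synthase, inducible (Homo sapiens), read by scintillation counting, with a stated time of 30 min, tested at 1 mM; on this read-out lower numbers stand for less inhibition and higher numbers for more inhibition at the one concentration tested (going by the name of the read-out):
compound 1 `CCC(=O)NCCC(=O)c1cc(OC)ccc1N` gives 0.24%
compound 2 `CCCCC(=O)NCCC(=O)c1cc(OC)ccc1N` gives 14.1%
compound 3 `COc1ccc(N)c(C(=O)CCNC(=O)C2CCC2)c1` gives 0.01%

Compound 3 sits lowest of the three numbers, though a number 0.2 percentage points lower from compound 1 to compound 3 (within the scatter) places it within the scatter of compound 1, while a number 14.1 percentage points lower from compound 2 to compound 3 (beyond the scatter) sets it apart from compound 2 by a modest step.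

Compound 4 `COc1ccc(N)c(C(=O)CCNC(=O)C2CCCC2)c1` differs from compound 3 only in the group on the amide carbonyl: cyclopentyl in place of cyclobutyl on a carbonyl carbon.

The bearing steps are a number 13.9 percentage points higher from compound 1 to compound 2 (beyond the scatter), a modest rise with a longer chain, and a number 14.1 percentage points lower from compound 2 to compound 3 (beyond the scatter), a modest fall on going to the smaller ring. A larger ring may therefore move the read-out upward by a small to modest amount, or not beyond the scatter.

Compound 4 is expected near 5%, within -5% to 20%, an estimated step of a number 5 percentage points higher from compound 3 to compound 4 (within the scatter) in this assay.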

Compound 4, a percentage reported as inhibition, at one concentration (the size of the read-out at that concentration, not a potency): 0.61%
Estimate against measurement, compound 4: 4.4 percentage points above; low and high end bracket the measured number.
By their numbers in this assay, from the lowest: compounds 3, 1 and 4 (each within the scatter of the next); then compound 2.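

In this assay, the larger ring at this carbonyl carbon gives no readable change, with a number 0.6 percentage points higher from compound 3 to compound 4 (within the scatter), and cyclopentyl also stays level with ethyl, with a number 0.4 percentage points higher from compound 1 to compound 4 (within the scatter). Butyl remains the only group of the four set apart, with a number 13.5 percentage points lower from compound 2 to compound 4 (beyond the scatter), so two ring sizes now fall short of the open chain. No evidence on the cause of this difference is at hand.

Open, from the compounds shown here alone, is whether a cyclohexyl ring stays at this level, and whether a hexyl chain goes beyond butyl.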